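Para-substituent swaps on the shared core: next step

This account rests on a few compounds, and the source may have more. Where it says the series, first, only, none or still open, it means among the compounds named here.

Going by the values given here, compound 1 `COc1ccc(-c2cc(=O)c3c(O)cc(OCCCCN4CCN(C)CC4)c(OC)c3o2)cc1` gives 3980 nM in a functional assay on MCF7 cells (Homo sapiens) for cytotoxicity, read by MTT assay, with a stated time of 72 h (a higher number here means a weaker inhibitor, a lower number a stronger inhibitor), and stands second highest of the three numbers so far. Compound 2 `COc1c(OCCCCN2CCN(C)CC2)cc(O)c2c(=O)cc(-c3ccc([N+](=O)[O-])cc3)oc12` gives 4090 nM and compound 3 `COc1c(OCCCCN2CCN(C)CC2)cc(O)c2c(=O)cc(-c3ccc(Br)cc3)oc12` gives 3210 nM in this assay. The three measured steps, a 1.0-fold higher number from compound 1 to compound 2 (0.01 log units; within the scatter), a 1.2-fold lower number from compound 1 to compound 3 (0.09 log units; within the scatter) and a 1.3-fold lower number from compound 2 to compound 3 (0.11 log units; within the scatter), all sit within the scatter, so the three exchanges on the pendant aryl ring leave the number essentially unchanged. Compound 4 `COc1c(OCCCCN2CCN(C)CC2)cc(O)c2c(=O)cc(-c3ccc(F)cc3Br)oc12` carries a double exchange at the same place: 2-bromo-4-fluorophenyl in place of 4-methoxyphenyl on an aromatic carbon. All bearing steps being flat, no step beyond the scatter is expected in this assay. The expectation for compound 4 is therefore 3600 nM, with a range from 1800 nM to 7500 nM, a step of a 1.1-fold lower number from compound 1 to compound 4 (0.04 log units; within the scatter) that is expected to stay within the scatter.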

Compound 4, half-maximal inhibitory concentration: 3090 nM
Beside the measured number, compound 4's estimate is 1.2-fold (0.07 log units) above it; measured number inside the range.
By their numbers in this assay, from the lowest: compounds 4, 3, 1 and 2 (each within the scatter of the next).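

Going by these compounds alone, compound 4 puts two substituents on the pendant aryl ring where the earlier compounds carry one, and in this assay the steps of a 1.3-fold lower number from compound 1 to compound 4 (0.11 log units; within the scatter) and a 1.0-fold lower number from compound 3 to compound 4 (0.02 log units; within the scatter) and a 1.3-fold lower number from compound 2 to compound 4 (0.12 log units; within the scatter) all stay within the scatter. Within the data shown here, this position therefore accepts the 2-bromo-4-fluorophenyl double exchange as readily as the single swaps, with no step yet beyond the scatter. Nothing at hand explains this flat response.

Open, from the compounds shown here alone, is whether an amine or a carboxylic acid on this ring would leave the number equally flat. Also open, going by these compounds, is whether replacing the aryl ring with a saturated ring such as cyclohexyl would do so.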